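The source may hold more compounds than are shown below. What is called first, only, known or untested is meant among the compounds shown, and "the series" means these compounds.

Working notes on the series. Of the compounds shown here, two have been measured in a physicochemical assay for solubility, read by HPLC, in simulated intestinal fluid, with a stated time of 3 days, at pH 6.8; a lower number here means a less soluble compound, a higher number a more soluble compound. Compound 1, `Cn1cc(C(=O)Nc2ccc(-c3ccccc3)c(C(F)(F)F)c2)c(=O)c2cnccc21`, gives 5 ug/mL. Compound 2, `Cn1cc(C(=O)Nc2ccc(-c3ccccc3)c(C(F)(F)F)c2)c(=O)c2ccc(CCO)cc21`, gives 6 ug/mL. Among the measured compounds shown here, the two values lie within the scatter of each other, so the numbers so far separate nothing; compound 2 is simply the one from which the next step is taken.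

The next step goes to compound 3, `Cn1cc(C(=O)Nc2ccc(-c3ccccc3)c(C(F)(F)F)c2)c(=O)c2ccc(CCC(=O)O)cc21`. The difference from compound 2 is carboxy in place of hydroxy on a saturated chain carbon, two bonds along the chain from an aromatic carbon. For the measured compounds named here, no step between measured compounds covers this kind of change, so there is no precedent to lean on.

With a carboxy entering in place of a hydroxy on the chain, the step from compound 2 to compound 3 is expected to move upward in this assay, beyond the scatter, by about a 6.7-fold higher number from compound 2 to compound 3 (0.82 log units; beyond the scatter). Compound 3 is therefore estimated at 40 ug/mL, with a range from 8 ug/mL to 200 ug/mL.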

Compound 3, solubility: 200 ug/mL
Beside the measured number, compound 3's estimate is 5.0-fold (0.70 log units) below it; low and high end bracket the measured number.
By their numbers in this assay, from the lowest: compounds 1 and 2 (each within the scatter of the next); then compound 3.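

Carboxy in place of hydroxy on a saturated chain carbon, two bonds along the chain from an aromatic carbon, gives a 33-fold higher number from compound 2 to compound 3 (1.52 log units; beyond the scatter) in this assay and is the first step in the series to lie beyond the scatter. Compound 1 and compound 2 gave no such separation, so this chain is the first place shown where a single change moves the number, and the move is large. The data shown offer no explanation for the size of this step.

As far as these compounds go, whether an amine or a tetrazole in the same place on the chain would give a comparable step remains open, as does the outcome with the carboxy on a shorter or longer chain. Also open, from the compounds shown here alone, is whether a carboxyethyl group on the core of compound 1 would give a step of similar size.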